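The source may report more compounds than this note shows. Statements on the series, on what has been measured and on what is new or still open speak of the compounds shown alone.

Measured in a functional assay on A549 cells (Homo sapiens) for cytotoxicity, read by CCK-8 assay; a lower number here means a stronger inhibitor, a higher number a weaker inhibitor:
- compound 1 `O=C(Nc1cccc(O)c1)c1ncc(-c2ccccc2)o1`: > 30000 nM
- compound 2 `COc1ccc(NC(=O)c2ncc(-c3ccccc3)o2)cc1`: > 30000 nM

In this assay, compound 2 gives > 30000 nM, which is a limit of the assay and not a number. Compound 1 gives > 30000 nM, which is also a limit. Both compounds therefore sit at the limit of > 30000 nM in this assay, at which 2 of the 2 values shown sit, and no number yet places either of them on the scale.

Compound 3 `O=C(Nc1ccc(Cl)cc1)c1ncc(-c2ccccc2)o1` keeps the core of compound 2 and changes a single group: chloro in place of methoxy on an aromatic carbon, para to a large group (chloro in place of methoxy on an aromatic carbon). Within the data shown here, no measured pair in this small set shows what such a change does, so any expectation here is tentative. A small shift toward stronger inhibition in this assay is expected, and compound 3 may well remain at the limit too. The expected step is an at least 1.2-fold lower number from compound 2 to compound 3 (0.07 log units; that floor lies within the scatter), which is a modest one. For compound 3 the estimated value is 25000 nM, with an expected range of 8000 nM to 60000 nM.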

Compound 3, half-maximal inhibitory concentration: > 30000 nM
Compound 3: no number, only a limit (the forecaster's own chance of this, stated with the estimate: 55%); at least 1.2-fold (0.07 log units) between middle value and limit.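

In this assay, among these compounds, compound 3 gives a limit and not a number, as do compound 1 and compound 2, so no step from either of those compounds to compound 3 can be read: the limit of > 30000 nM in this assay, at which 3 of the 3 values shown sit. The compounds shown leave open where any of the three falls on the scale, and what chloro in place of methoxy does in this assay once a number is available.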